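The compounds below may be only part of what the source reports. "The series", "measured", "known", "first", "only" and "open" are said of these compounds alone.

Of the compounds shown here, two of a shared urea-linked core have been measured, and a third awaits its number. Compound 1 `COc1cc(NC(=O)Nc2cc(Nc3ccc(C)c(F)c3)ncn2)cc(OC)c1` carries a 3-fluoro-4-methylphenyl group on the amine nitrogen of the core and a dimethoxyphenyl urea on the other side. In a functional assay on NCI-H1581 cells (Homo sapiens) for inhibition, read by MTT assay, with a stated time of 48 h, tested at 10 uM (a higher number here means more inhibition at the concentration tested (going by the name of the read-out), a lower number less inhibition), compound 1 gives 38%. Compound 2 `O=C(Nc1cc(Nc2ccc(F)c(Cl)c2)ncn1)Nc1c(Cl)cccc1Cl` differs from compound 1 at both ends of the core; in this assay compound 2 gives 67%. Compound 1 thus stands lowest of the two numbers shown, and the gap to compound 2 lies beyond the usual scatter of this measurement; with two positions changed at once, the two values show only that much and no single step can be read from them.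

The untested compound 3 `COc1cc(NC(=O)Nc2cc(Nc3ccc(OC)c(I)c3)ncn2)cc(OC)c1` keeps the dimethoxyphenyl urea of compound 1 and changes only the amine substituent: 3-iodo-4-methoxyphenyl in place of 3-fluoro-4-methylphenyl on a nitrogen on an aromatic ring. Going by the values given here, no measured pair isolates a change of this kind, so there is no step on which to rest firmly. The size of the replacement, with a heavier halogen and an added hydrogen-bond acceptor entering, might lift inhibition somewhat, but the step from compound 1 to compound 3 is expected to be small, a number 7 percentage points higher from compound 1 to compound 3 (within the scatter), and could as well fall within the scatter. Compound 3 is therefore estimated at 45% in this assay, with a plausible range from 22% to 68%.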

Compound 3, a percentage reported as inhibition, at one concentration (the size of the read-out at that concentration, not a potency): 43%
Estimate against measurement, compound 3: 2 percentage points above; the measured number falls inside the stated range.
By their numbers in this assay, from the lowest: compounds 1 and 3 (each within the scatter of the next); then compound 2.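

With compound 3, the series gains its first step that changes one place only: the group on a nitrogen on an aromatic ring, while the dimethoxyphenyl urea stays the same. In this assay putting 3-iodo-4-methoxyphenyl in place of 3-fluoro-4-methylphenyl gives a number 5 percentage points higher from compound 1 to compound 3 (within the scatter) and so shows that this exchange, which brings in iodine and a methoxy oxygen and removes fluorine and a methyl group, leaves the read-out unchanged within the scatter at the concentration tested. Nothing measured here offers an explanation for this result.

Going by these compounds alone, the single step speaks for these two groups only, and whether a morpholine or a carboxylic acid carried on the same phenyl ring would leave the number equally unmoved stays open. With compound 2 at 67% and differing from compound 1 and compound 3 at both ends of the shared core, how much of that value belongs to its 2,6-dichlorophenyl urea and how much to its 3-chloro-4-fluorophenyl group cannot be read from the compounds shown.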